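Swapping Nitro for Acetamido on a Sulfonyl Aryl Ring

The source may hold more compounds than are shown below. What is called first, only, known or untested is meant among the compounds shown, and "the series" means these compounds.

In a functional assay on QGY-7703 cells (Homo sapiens) for cytotoxicity, read by MTT assay, with a stated time of 24 h (on this read-out higher numbers stand for weaker inhibition and lower numbers for stronger inhibition), compound 1 (`CN1C/C(=C\c2ccncc2)C(=O)/C(=C/c2ccccc2C(F)(F)F)C1`) gives 4500 nM and compound 2 (`O=C1/C(=C/c2ccncc2)CNC/C1=C\c1ccccc1C(F)(F)F`) gives 4900 nM, which lie within the scatter of each other. Compound 3 (`O=C1/C(=C/c2ccncc2)CN(S(=O)(=O)c2ccc([N+](=O)[O-])cc2)C/C1=C\c1ccccc1C(F)(F)F`), which carries a (4-nitrophenyl)sulfonyl group on the ring nitrogen, gives 9730 nM. That is a 2.2-fold higher number from compound 1 to compound 3 (0.33 log units; beyond the scatter), a modest step, and a 2.0-fold higher number from compound 2 to compound 3 (0.30 log units; within the scatter). Compound 3 therefore stands clearly apart only from compound 1.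

Compound 4 (`CC(=O)Nc1ccc(S(=O)(=O)N2C/C(=C\c3ccncc3)C(=O)/C(=C/c3ccccc3C(F)(F)F)C2)cc1`) has acetamido in place of nitro on an aromatic carbon. Within the data shown here, no measured step tests this exchange directly. The nearest guides are those two steps, in which the entire group on the ring nitrogen was replaced and the number still moved only slightly. Changing one substituent on that group should therefore matter no more than this. The expected step is a 1.3-fold lower number from compound 3 to compound 4 (0.11 log units; within the scatter), a slight move towards a lower number that is not expected to exceed the scatter. The estimate for compound 4 is 7500 nM, with an expected range from 3000 nM to 17000 nM.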

Compound 4, half-maximal inhibitory concentration: 5560 nM
Beside the measured number, compound 4's estimate is 1.3-fold (0.13 log units) above it; measured number inside the range.
By their numbers in this assay, from the lowest: compounds 1, 2, 4 and 3 (each within the scatter of the next, the first and the last beyond it).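

The step of a 1.8-fold lower number from compound 3 to compound 4 (0.24 log units; within the scatter) is the only one shown that changes a single substituent within the group on the ring nitrogen, whereas the earlier steps replaced that whole group. It shows that in this assay nitro can give way to acetamido on the aromatic carbon para to a large group without the number leaving the scatter, even though acetamido has more heavy atoms and brings a hydrogen-bond donor that nitro lacks. Nothing measured here bears on why the number stays within the scatter.

Still open, going by these compounds, is whether an amine or a carboxylic acid at this same position would move the number beyond the scatter. A longer chain in place of the acetyl part of acetamido is equally untested by the compounds shown.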